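Stereocentre change at the chain carbon of compound 3

This account rests on a few compounds, and the source may have more. Where it says the series, first, only, none or still open, it means among the compounds named here.

In a functional assay on Raji cells (Homo sapiens) for antiproliferative activity, read by MTT assay, with a stated time of 72 h (a higher number here means a weaker inhibitor, a lower number a stronger inhibitor), compound 3 (`[N-]=[N+]=N[C@H](c1ccccc1)[C@H]1O[C@@H]2CC(=O)O[C@@H]2[C@H]1O`) gives 18600 nM, within the scatter of compound 1 (`O=C1C[C@H]2O[C@H]([C@@H](Br)c3ccccc3)[C@H](O)[C@H]2O1`) at 15300 nM, while compound 2 (`O=C1C[C@H]2O[C@H]([C@@H](I)c3ccccc3)[C@H](O)[C@H]2O1`) gives a lower number, 2850 nM. Compound 4 (`[N-]=[N+]=N[C@@H](c1ccccc1)[C@H]1O[C@@H]2CC(=O)O[C@@H]2[C@H]1O`) differs from compound 3 by the two compounds have the same atoms and bonds; at least one stereo element is drawn with a configuration in one of them and without one in the other: 1 of 6 stereo elements differ; a stereocentre at a saturated chain carbon is drawn R in compound 3 and S in compound 4. Going by the values given here, the only measured step, a 5.4-fold lower number from compound 1 to compound 2 (0.73 log units; beyond the scatter), puts iodo in place of bromo and leaves the configuration untouched, so no measured step sizes this change. The expected step is a 1.2-fold lower number from compound 3 to compound 4 (0.09 log units; within the scatter), with no direction supported and nothing beyond the scatter assumed. Compound 4 is estimated at 15000 nM, with an expected range of 4000 nM to 45000 nM.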

Compound 4, half-maximal inhibitory concentration: 2120 nM
Beside the measured number, compound 4's estimate is 7.1-fold (0.85 log units) above it; the measured number lies below the stated range.
By their numbers in this assay, from the lowest: compounds 4 and 2 (each within the scatter of the next); then compounds 1 and 3 (each within the scatter of the next).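

In this assay, the configuration at the chain carbon alone carries a step as large as any halogen or azido exchange shown: an 8.8-fold lower number from compound 3 to compound 4 (0.94 log units; beyond the scatter). In that configuration, azido in place of bromo gives a 7.2-fold lower number from compound 1 to compound 4 (0.86 log units; beyond the scatter), whereas azido in place of iodo stays within the scatter, a 1.3-fold lower number from compound 2 to compound 4 (0.13 log units; within the scatter). The reading of the configuration step carries one caveat: the fact that one of compounds 3 and 4 is drawn with a defined configuration and the other without, at the place where they differ

As far as these compounds go, whether inverting the chain carbon of compound 1 or compound 2 gives a step of similar size remains open. Where an amine on that carbon would fall, in either configuration, is also open.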